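From 4-fluorobenzyl to isopropyl on an amine nitrogen

This account rests on a few compounds, and the source may have more. Where it says the series, first, only, none or still open, it means among the compounds named here.

In a functional assay on DLD-1 cells (Homo sapiens) for inhibition, read by MTT assay, with a stated time of 72 h (a higher number here means a weaker inhibitor, a lower number a stronger inhibitor), compound 1 `COc1cc(Oc2cccc(Nc3ccccc3)c2)cc(OC)c1CNCc1ccc(F)cc1` gives 2650 nM. Compound 3 `COc1ccc(CCCNCc2c(OC)cc(Oc3cccc(Nc4ccccc4)c3)cc2OC)cc1` gives 2540 nM, within the scatter of that value. Compound 2 `COc1cc(Oc2cccc(Nc3ccccc3)c2)cc(OC)c1CNCc1ccc(C)cc1` gives 6080 nM, the highest number of the three.

Compound 4 `COc1cc(Oc2cccc(Nc3ccccc3)c2)cc(OC)c1CNC(C)C` has not yet been measured. Its difference from compound 1 is isopropyl in place of 4-fluorobenzyl on an amine nitrogen. In words, this is isopropyl in place of 4-fluorobenzyl on an amine nitrogen, so the aromatic ring of the departing group is lost.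

Three measured steps offer a guide. The first is a 2.3-fold higher number from compound 1 to compound 2 (0.36 log units; beyond the scatter), the second is a 2.4-fold lower number from compound 2 to compound 3 (0.38 log units; beyond the scatter), and the third, a 1.0-fold lower number from compound 1 to compound 3 (0.02 log units; within the scatter), is too small to count as a change. For the measured compounds named here, all three compounds keep an aromatic ring in this part of the molecule, so no measured step shows what removing it does. The steps therefore give only a rough size, and the direction is a cautious guess. A modest move towards a higher number, meaning a weaker inhibitor, seems most likely. The expected step is a 2.3-fold higher number from compound 1 to compound 4 (0.35 log units; beyond the scatter), and a wide range allows for the missing evidence. Compound 4 is estimated at 6000 nM, with an expected range from 2000 nM to 18000 nM.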

Compound 4, half-maximal inhibitory concentration: > 20000 nM
Compound 4 was reported as a limit; the forecaster's own chance of this, stated with the estimate: 10%; at least 3.3-fold (0.52 log units) between middle value and limit.
By their numbers in this assay, from the lowest: compounds 3 and 1 (each within the scatter of the next); then compound 2. At a limit, above all of these: compound 4.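

In this assay compound 4 is reported as a limit, not as a number: the limit of > 20000 nM in this assay, at which 1 of the 4 values shown sits.

The earlier compounds shown here all keep an aromatic ring on the group at this amine nitrogen, and the steps among them are modest at most, so they gave no view of what happens without that ring. Isopropyl, which has no ring, brings a much larger change, seen in an at least 7.5-fold higher number from compound 1 to compound 4 (0.87 log units; beyond the scatter) and in an at least 7.8-fold higher number from compound 3 to compound 4 (0.89 log units; beyond the scatter) and in an at least 3.2-fold higher number from compound 2 to compound 4 (0.51 log units; beyond the scatter), all beyond the scatter. Among these four compounds, then, the three with an aromatic ring in this group give measurable numbers, while the one with a small ring-free group reaches the limit of the assay.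

The compounds shown leave open whether the aromatic ring itself matters or simply the size of the group, since isopropyl has fewer heavy atoms than 4-fluorobenzyl as well as no ring. From the compounds shown here alone, a cyclohexylmethyl group, which keeps a ring that is not aromatic, or a longer chain such as hexyl, on the same amine nitrogen would help to separate the two, and the true size of these steps stays unknown while compound 4 is given only as a limit.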